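Kinetic solubility in a quinoline-aryloxyacetamide series: methyl additions

The compounds below may be only part of what the source reports. "The series", "measured", "known", "first", "only" and "open" are said of these compounds alone.

Compound 1 `Cc1cc(C)cc(NC(=O)COc2cc(C)nc3ccccc23)c1` is the reference of the set. In a physicochemical assay for solubility, in phosphate buffer, measured as kinetic solubility, with a stated time of 1 h, at pH 7.4 (on this read-out higher numbers stand for higher solubility and lower numbers for lower solubility), compound 1 gives 55000 nM. Compound 2 `Cc1cc(C)cc(NC(=O)COc2cc(C)nc3ccc(C)cc23)c1` carries the change methyl in place of hydrogen on an aromatic carbon and in this assay compound 2 gives 83000 nM, a step of a 1.5-fold higher number from compound 1 to compound 2 (0.18 log units; within the scatter). Compound 3 `COc1ccc2nc(C)cc(OCC(=O)Nc3cccc(C)c3)c2c1` sits on a different core; how the two cores differ is not broken down here. In this assay compound 3 gives 193000 nM, the highest number of the three measured, beyond the scatter from both compound 2 and compound 1.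

Compound 4 `COc1ccc2nc(C)cc(OCC(=O)Nc3cc(C)ccc3C)c2c1` is not yet measured. It differs from compound 3 by methyl in place of hydrogen on an aromatic carbon, the same kind of change as from compound 1 to compound 2, but at a different place: there the methyl sits meta to a fused ring and para to a fused ring, here ortho to a large group and para to a methyl group. On the evidence of a 1.5-fold higher number from compound 1 to compound 2 (0.18 log units; within the scatter), a step of a 1.1-fold lower number from compound 3 to compound 4 (0.06 log units; within the scatter) is expected in this assay, resting on a single earlier example. For compound 4 a value of 170000 nM is estimated in this assay, between 70000 nM and 400000 nM.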

Compound 4, solubility: 45500 nM
For compound 4 the middle estimate is 3.7-fold (0.57 log units) above the measured one, outside the stated range (below it).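

In this assay, methyl in place of hydrogen on an aromatic carbon gives a 4.2-fold lower number from compound 3 to compound 4 (0.63 log units; beyond the scatter) and so lies beyond the scatter, whereas the same kind of change on the core of compound 1 gives a 1.5-fold higher number from compound 1 to compound 2 (0.18 log units; within the scatter) and stays within it; a step read on one core therefore did not carry over to the other in this single pair of examples. It does not show whether the core or the place of the methyl sets the gap, since the two steps differ in both, and the step to compound 4 is the 3-methylphenyl to 2,5-dimethylphenyl change at one place only. Nothing available bears on what lies behind the step to compound 4.

Still open, going by these compounds, is whether the 3-methylphenyl to 2,5-dimethylphenyl change gives a comparable step on the core of compound 1, which would separate core from place. Also open, on these data alone, is how an amine or a carboxylic acid at the same place on the core of compound 3 would read in this assay against the methyl of compound 4.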